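The source may report more compounds than this note shows. Statements on the series, on what has been measured and on what is new or still open speak of the compounds shown alone.

Compound 1 `COC(=O)[C@@]1(C)CCC=C2[C@@H]1CC[C@@H](C)[C@]2(C)Cc1c[nH]c2ccccc12` and compound 2 `COC(=O)[C@@]1(C)CCC=C2[C@@H]1CC[C@@H](C)[C@]2(C)Cc1c[nH]c2ccc(C)cc12` share one core and differ only in that compound 2 carries a methyl in place of hydrogen on an aromatic carbon. In a functional assay on WiDr cells (Homo sapiens) for inhibition, read by sulforhodamine B assay, with a stated time of 48 h (a lower number here means a stronger inhibitor of growth, a higher number a weaker inhibitor of growth), compound 1 gives 8700 nM, and compound 2 gives 22000 nM; the step between them is a 2.5-fold higher number from compound 1 to compound 2 (0.40 log units; beyond the scatter). Compound 2 thus stands with the higher of the two numbers, its nearest neighbour being compound 1. Compound 3 `COC(=O)[C@@]1(C)CCC=C2[C@@H]1CC[C@@H](C)[C@]2(C)Cc1c[nH]c2ccc(Br)cc12` follows from compound 2 by a single exchange: bromo in place of methyl on an aromatic carbon. Among the measured compounds shown here, no measured step exchanges methyl for bromo at an aromatic carbon, so the only guide is that compound 1 and compound 2 differ at the same aromatic carbon, where a 2.5-fold higher number from compound 1 to compound 2 (0.40 log units; beyond the scatter) was modest. Because compound 2 gives 22000 nM, compound 3 is expected to land near it, with a 1.1-fold lower number from compound 2 to compound 3 (0.04 log units; within the scatter) a step not expected to go beyond the scatter in either direction. Compound 3 is therefore estimated at 20000 nM in this assay, within a range from 8000 nM to 60000 nM.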

Compound 3, concentration for 50% growth inhibition: 20000 nM
The estimate for compound 3 equals the measured number at the digits printed; the measured number falls inside the stated range.
By their numbers in this assay, from the lowest: compound 1; then compounds 3 and 2 (each within the scatter of the next).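

In this assay, the exchange of methyl for bromo at this aromatic carbon gives a 1.1-fold lower number from compound 2 to compound 3 (0.04 log units; within the scatter) and so leaves the two groups indistinguishable in this read-out. Bromo in place of hydrogen at the same carbon gives a 2.3-fold higher number from compound 1 to compound 3 (0.36 log units; beyond the scatter) as a modest step, so the higher number seen with methyl is not confined to that one group: both substituents shown here stand apart from the hydrogen of compound 1, and none of the three compounds goes against this. Nothing at hand says why methyl and bromo behave alike at this carbon or why either differs from hydrogen.

Three compounds cannot show whether any group at this carbon would match or improve on the hydrogen of compound 1, and a hydroxyl, an amine, a carboxylic acid or a longer chain could each answer differently from methyl and bromo. Going by these compounds, it also remains open whether bromo or methyl would give a similar result on another aromatic carbon of the same ring, or whether the pattern would hold if the methyl ester of the shared core were replaced by a carboxylic acid.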